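Swapping the Amine Substituent and Mouse Microsomal Clearance

The source may report more compounds than this note shows. Statements on the series, on what has been measured and on what is new or still open speak of the compounds shown alone.

Three compounds share one core and differ only in the group carried on a saturated chain carbon bound to a double-bonded ring carbon. Compound 1 `COC(=O)C1=C(CN2CCOCC2=O)NC(c2nccs2)=NC1(C)c1ccc(F)cc1` carries 3-oxomorpholin-4-yl there; in an ADME assay on microsomes from liver (Mus musculus) for metabolic stability, read by LC-MS, using NADPH, with stated times of 10 min and 30 min, tested at 1 uM (a higher number here means faster removal of the compound, a lower number slower removal), compound 1 gives 80 mL/min/kg. Compound 2 `COC(=O)C1=C(CN2CCC(O)C2)NC(c2nccs2)=NC1(C)c1ccc(F)cc1` gives 83 mL/min/kg, and compound 3 `COC(=O)C1=C(CN2CCC(C(F)(F)F)C2)NC(c2nccs2)=NC1(C)c1ccc(F)cc1` gives 88 mL/min/kg. Compound 1 has the lowest of the three numbers, yet the step of a 1.0-fold higher number from compound 1 to compound 2 (0.02 log units; within the scatter) and the step of a 1.1-fold higher number from compound 1 to compound 3 (0.04 log units; within the scatter) both lie within the scatter, as does a 1.1-fold higher number from compound 2 to compound 3 (0.03 log units; within the scatter), so these three compounds cannot be told apart on this measure.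

Compound 4 `COC(=O)C1=C(CN(C)C2(C(=O)O)CC2)NC(c2nccs2)=NC1(C)c1ccc(F)cc1` is not yet measured. It differs from compound 1 as follows: a group of 8 heavy atoms (5 carbon, 1 nitrogen, 2 oxygen; one three-membered non-aromatic ring of carbon only) in place of a group of 7 heavy atoms (4 carbon, 1 nitrogen, 2 oxygen; one six-membered non-aromatic ring with 2 hetero atoms), on a saturated chain carbon bound to a double-bonded ring carbon. Among the compounds with values here, none of the measured steps makes exactly this change; the nearest guides are the two replacements of 3-oxomorpholin-4-yl, a 1.0-fold higher number from compound 1 to compound 2 (0.02 log units; within the scatter) and a 1.1-fold higher number from compound 1 to compound 3 (0.04 log units; within the scatter), both within the scatter. On that basis no step beyond the scatter is expected, a 1.1-fold lower number from compound 1 to compound 4 (0.06 log units; within the scatter). Compound 4 is therefore estimated at 70 mL/min/kg, within 35 mL/min/kg to 140 mL/min/kg.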

Compound 4, clearance: 42 mL/min/kg
Beside the measured number, compound 4's estimate is 1.7-fold (0.22 log units) above it; measured number inside the range.
By their numbers in this assay, from the lowest: compounds 4, 1, 2 and 3 (each within the scatter of the next, the first and the last beyond it).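

Within the data shown here, at the position on a saturated chain carbon bound to a double-bonded ring carbon, the earlier replacements all gave steps within the scatter, but the group in compound 4, with its three-membered non-aromatic ring of carbon only, gives the first step beyond it in this assay: a 2.1-fold lower number from compound 3 to compound 4 (0.32 log units; beyond the scatter), a modest one. The other two steps, a 1.9-fold lower number from compound 1 to compound 4 (0.28 log units; within the scatter) and a 2.0-fold lower number from compound 2 to compound 4 (0.30 log units; within the scatter), stay within the scatter, so this position shows a real difference only against compound 3. Nothing measured here gives a reason for that step.

The compounds shown leave open which part of the entering group goes with the lower number, the three-membered ring or the carboxylic acid. An open chain carrying the carboxylic acid, or a primary amide in place of that acid, would help separate the two.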